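Mirror-Image Inversion and Clearance in Liver Microsomes

This account rests on a few compounds, and the source may have more. Where it says the series, first, only, none or still open, it means among the compounds named here.

Compound 1, `Cn1ccc(-c2cn3nccc3c(-c3cnn([C@]4(CC#N)C[C@@H](C#N)C4)c3)n2)n1`: in an ADME assay on microsomes from liver (Homo sapiens) for pharmacokinetics (a higher number here means faster removal of the compound, a lower number slower removal), compound 1 gives < 8 uL/min, which is a limit of the assay.
Compound 2, `Cn1ccc(-c2cn3nccc3c(-c3cnn([C@]4(CC#N)C[C@H](C#N)C4)c3)n2)n1`: in this assay compound 2 gives 23 uL/min.
Compound 3, `N#CC[C@]1(n2cc(-c3nc(-c4cc[nH]n4)cn4nccc34)cn2)C[C@H](C#N)C1`: in this assay compound 3 gives < 8 uL/min, which is a limit of the assay.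

Compound 3 thus stands at the floor of what this assay reports; this is the limit of < 8 uL/min in this assay, at which 2 of the 3 values shown sit. The step that the two limits leave unreadable from compound 1 to compound 3 is therefore not readable. Compound 4, `N#CC[C@]1(n2cc(-c3nc(-c4cc[nH]n4)cn4nccc34)cn2)C[C@@H](C#N)C1`, differs from compound 3 as follows: the two compounds have the same atoms and bonds and differ only in configuration as drawn: 2 of 2 stereo elements differ (all stereocentres are inverted: mirror images); a stereocentre at a saturated ring carbon is drawn r in compound 3 and s in compound 4; a stereocentre at a saturated ring carbon is drawn r in compound 3 and s in compound 4. Within the data shown here, the one comparable measured step is an at least 2.8-fold higher number from compound 1 to compound 2 (0.45 log units; beyond the scatter), which counts because of the fact that compounds 1 and 2 differ only in the configuration as drawn. A rise of similar size is expected in this assay from compound 3 to compound 4: an at least 2.5-fold higher number from compound 3 to compound 4 (0.39 log units; beyond the scatter). Compound 4 is estimated to give 20 uL/min in this assay, expected between 8 uL/min and 45 uL/min.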

Compound 4, intrinsic clearance in a liver preparation (reported as CLH), per the amount of preparation that the assay uses in the Homo sapiens assay: 20 uL/min
Compound 4: the middle estimate sits on the measured number at the digits printed; low and high end bracket the measured number.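

In the Homo sapiens assay the rise on inversion recurs with hydrogen in place of methyl on the aromatic nitrogen, as an at least 2.5-fold higher number from compound 3 to compound 4 (0.39 log units; beyond the scatter), and configuration as drawn is the only difference: the fact that compounds 3 and 4 differ only in the configuration as drawn. For the inverted pair, the same hydrogen-for-methyl change gives a 1.2-fold lower number from compound 2 to compound 4 (0.06 log units; within the scatter). In a physicochemical assay for lipophilicity, using the shake flask method, in phosphate buffer, measured as octanol-water partition, at pH 7.4 (on this read-out lower numbers stand for lower lipophilicity and higher numbers for higher lipophilicity), compound 3 gives 1.7 and compound 4 gives 1.7, which is no change at the digits printed from compound 3 to compound 4 (within the scatter).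

On these data alone, whether the inversion step holds with an ethyl group on that aromatic nitrogen, or with an amide in place of a nitrile, stays open.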